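The source may hold more compounds than are shown below. What is called first, only, known or untested is meant among the compounds shown, and "the series" means these compounds.

Measured in an assay (Rattus norvegicus) for inhibition of Fatty-acid amide hydrolase 1 (Homo sapiens); a lower number here means a stronger inhibitor, a higher number a weaker inhibitor:
Compound 1 `N#Cc1ccccc1-c1cnc(C(=O)CCCCCCc2ccccc2)o1` gives 130 nM.
Compound 2 `Nc1cccc(-c2cnc(C(=O)CCCCCCc3ccccc3)o2)c1` gives 19 nM.
Compound 3 `COc1ccc(-c2cnc(C(=O)CCCCCCc3ccccc3)o2)cc1` gives 100 nM.

Compound 3 holds the second highest of the three numbers; against compound 1 the gap is within the scatter, as a 1.3-fold lower number from compound 1 to compound 3 (0.11 log units; within the scatter) shows, whereas a 5.3-fold higher number from compound 2 to compound 3 (0.72 log units; beyond the scatter) is a modest step beyond it. Compound 4 `NC(=O)c1ccc(-c2cnc(C(=O)CCCCCCc3ccccc3)o2)cc1` differs from compound 3 by carbamoyl in place of methoxy on an aromatic carbon, on an aromatic carbon para to a large group. The steps bearing on this are a 1.3-fold lower number from compound 1 to compound 3 (0.11 log units; within the scatter) and a 5.3-fold higher number from compound 2 to compound 3 (0.72 log units; beyond the scatter): the only variant beyond the scatter was compound 2, which carries a hydrogen-bond donor, and compound 4 likewise gains one. A modest lowering in this assay is therefore expected for compound 4, a 1.7-fold lower number from compound 3 to compound 4 (0.22 log units; within the scatter). Compound 4 is estimated at 60 nM, in the range 15 nM to 250 nM.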

Compound 4, inhibition constant: 10 nM
Compound 4: the middle estimate sits 6.0-fold (0.78 log units) above what was measured; measured number below the stated range.
By their numbers in this assay, from the lowest: compounds 4 and 2 (each within the scatter of the next); then compounds 3 and 1 (each within the scatter of the next).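

In this assay, carbamoyl in place of methoxy gives a 10-fold lower number from compound 3 to compound 4 (1.00 log units; beyond the scatter) on this aromatic carbon para to a large group, so a change at this one place can move the number well beyond the scatter. The step of a 13-fold lower number from compound 1 to compound 4 (1.11 log units; beyond the scatter) is the only large one in the set, while a 1.9-fold lower number from compound 2 to compound 4 (0.28 log units; within the scatter) leaves the 4-carbamoylphenyl and 3-aminophenyl compounds level. Nothing in the data shown explains the size of these steps. On these data alone, whether a carboxylic acid or a methylamide at the same place would give a similar number remains open.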